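Adding Chloro to a Compound at the Limit

The source may report more compounds than this note shows. Statements on the series, on what has been measured and on what is new or still open speak of the compounds shown alone.

Values from a functional assay on HT-29 cells (Homo sapiens); on this read-out higher numbers stand for weaker inhibition of growth and lower numbers for stronger inhibition of growth:
- Compound 1 `O=S(=O)(/C=C/c1ccc(F)cc1)Cc1ccc(Nc2ncnc3ccccc23)cc1`: 1000 nM
- Compound 2 `O=S(=O)(/C=C/c1ccc(F)cc1F)Cc1ccc(Nc2ncnc3ccccc23)cc1`: > 100000 nM (a limit, not a number)
- Compound 3 `O=S(=O)(/C=C/c1ccc(O)cc1)Cc1ccc(Nc2ncnc3ccccc23)cc1`: 2000 nM

Compound 2 has no number of its own and stands at the limit of > 100000 nM in this assay, at which 1 of the 3 values shown sits. Compound 4 `O=S(=O)(/C=C/c1ccc(F)cc1F)Cc1ccc(Nc2ncnc3cc(Cl)ccc23)cc1` is compound 2 with a single change to the shared core: chloro in place of hydrogen on an aromatic carbon. Among the compounds with values here, none of the measured compounds carries a chloro on the core, so no measured step shows this change directly.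

The nearest guidance is indirect. There is an at least 100-fold higher number from compound 1 to compound 2 (2.00 log units; beyond the scatter), and there is also an at least 50-fold lower number from compound 2 to compound 3 (1.69 log units; beyond the scatter). Both are large, so one small change can matter greatly among these compounds, but both lie in the phenyl group on the double-bonded chain, not on the core. By contrast, there is a 2.0-fold higher number from compound 1 to compound 3 (0.30 log units; within the scatter).

In this assay, a measurable result for compound 4 would therefore be expected to fall on the lower side of the limit of compound 2, meaning stronger inhibition of growth. Its size is very uncertain, and compound 4 may well return only a limit too. The expected change is an at least 3.3-fold lower number from compound 2 to compound 4 (0.52 log units; beyond the scatter). For compound 4 the estimated value is 30000 nM, with an expected range from 2000 nM to 100000 nM.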

Compound 4, concentration for 50% growth inhibition: > 100000 nM
Compound 4 was reported as a limit; the forecaster's own chance of this, stated with the estimate: 45%; middle value at least 3.3-fold (0.52 log units) from the limit.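

In this assay, compound 2 and compound 4 both give only a limit and not a number, so the step between them cannot be read: the limit of > 100000 nM in this assay, at which 2 of the 4 values shown sit.

The compounds shown leave open whether chloro in place of hydrogen on the shared core changes growth inhibition at all, including on a compound with a readable value, such as compound 1 or compound 3.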